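Oral Exposure Across Two Sulfonamide Cores

The source may hold more compounds than are shown below. What is called first, only, known or untested is meant among the compounds shown, and "the series" means these compounds.

Compound 1 `Cn1nccc1-c1cc(C(F)(F)F)ccc1[C@H]1CCc2cc(S(=O)(=O)Nc3ncccn3)ccc21`: 58%
Compound 2 `O=S(=O)(Nc1ncccn1)c1ccc2c(c1)OCC[C@@H]2c1ccc(C(F)(F)F)cc1-c1ccc(F)nc1`: 74%

In an ADME assay on the whole organism (Rattus norvegicus, strain Sprague-Dawley) for pharmacokinetics, read by LC-MS, with a stated time of 24 h, at a dose of 10 mg/kg by the oral route (on this read-out lower numbers stand for lower oral bioavailability and higher numbers for higher oral bioavailability), compound 2 stands highest of the two numbers; compound 1 sits lower by a gap beyond the usual scatter. Among the compounds with values here, the two measured compounds differ in two places, so no single step between them can be read off. Compound 3 `Cn1nccc1-c1cc(C(F)(F)F)ccc1[C@H]1CCOc2cc(S(=O)(=O)Nc3ncccn3)ccc21` keeps the core of compound 2 with 1-methyl-1H-pyrazol-5-yl in place of 6-fluoropyridin-3-yl on an aromatic carbon. A downward step is expected, a number 12 percentage points lower from compound 2 to compound 3 (beyond the scatter), because compound 1 with the same 1-methyl-1H-pyrazol-5-yl gives 58%. Compound 3 is estimated at 62%, within 45% to 80%.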

Compound 3, oral bioavailability: 100%
Beside the measured number, compound 3's estimate is 38 percentage points below it; the measured number lies above the stated range.
By their numbers in this assay, from the lowest: compound 1; then compound 2; then compound 3.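

In this assay the aromatic carbon ortho to a large group and meta to a trifluoromethyl group responds clearly to 1-methyl-1H-pyrazol-5-yl in place of 6-fluoropyridin-3-yl on the same core, with a number 26 percentage points higher from compound 2 to compound 3 (beyond the scatter). Compound 1 carries the same 1-methyl-1H-pyrazol-5-yl and gives 58% while compound 3 gives 100%, so this group does not go with a single number across the two cores. Nothing at hand accounts for the step.

Going by these compounds, how an amine or a carboxylic acid on this aromatic carbon would stand in this assay remains open.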